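Benzylsulfanyl to Allylsulfanyl on a Uridine Diphosphate Core

The source may report more compounds than this note shows. Statements on the series, on what has been measured and on what is new or still open speak of the compounds shown alone.

Measured so far:
Compound 1, `O=c1cc(I)n([C@@H]2O[C@H](COP(=O)(O)OP(=O)(O)O)[C@@H](O)[C@H]2O)c(=O)[nH]1`, gives 15 nM in an in vitro functional assay on 1321-N1 cells for agonist activity at P2Y purinoceptor 6 (Homo sapiens); on this read-out lower numbers stand for an effect already at smaller amounts and higher numbers for an effect only at larger amounts of compound.
Compound 2, `O=c1nc(SCc2ccccc2)ccn1[C@@H]1O[C@H](COP(=O)(O)OP(=O)(O)O)[C@@H](O)[C@H]1O`, gives 800 nM in this assay.

Both compounds share the same diphosphate sugar core and differ in the attachment on the ring above it. Of the two numbers, compound 2 stands at the higher one, meaning its effect appears only at larger amounts, while compound 1 lies well below it, a gap beyond the usual scatter. These two compounds differ in more than one place. No single structural change can be read out of that gap.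

Compound 3, `C=CCSc1ccn([C@@H]2O[C@H](COP(=O)(O)OP(=O)(O)O)[C@@H](O)[C@H]2O)c(=O)n1`, has not yet been measured. It differs from compound 2 in one place only: vinyl in place of phenyl on a saturated chain carbon bound to a sulfur. Read one bond further out, benzylsulfanyl becomes allylsulfanyl. Among the measured compounds shown here, no measured pair shows this change, so any expectation rests on compound 2 alone. A modest step toward a lower number is expected, at the edge of the scatter, a 2.0-fold lower number from compound 2 to compound 3 (0.30 log units; within the scatter). Compound 3 is therefore estimated at 400 nM, with a range from 100 nM to 2000 nM.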

Compound 3, half-maximal effective concentration: 560 nM
The estimate for compound 3 lay 1.4-fold (0.15 log units) below the measured number; the measured number falls inside the stated range.
By their numbers in this assay, from the lowest: compound 1; then compounds 3 and 2 (each within the scatter of the next).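

In this assay, replacing phenyl with vinyl on a saturated chain carbon bound to a sulfur gives a 1.4-fold lower number from compound 2 to compound 3 (0.15 log units; within the scatter), so benzylsulfanyl and allylsulfanyl cannot be told apart on this read-out. Compound 2 alone could not show this: the six-membered aromatic ring of carbon only can give way to a group with no ring without a change beyond the scatter, so within this pair the ring makes no clear difference to the number. Nothing in the available data offers a reason for this result.

From the compounds shown here alone, two groups at a single place cannot show how far this tolerance extends, so it remains open whether an amine, a carboxylic acid or a longer chain on the sulfur would leave the number where it is or shift it beyond the scatter. Going by these compounds, compound 1 differs from compound 2 and compound 3 in more than one place, so it cannot help answer that question, and the role of the sulfur itself, for example compared with an oxygen, also remains open.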